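From a branched amine to a methoxycarbonyl amine

The source may report more compounds than this note shows. Statements on the series, on what has been measured and on what is new or still open speak of the compounds shown alone.

In a functional assay on MCF7 cells (Homo sapiens) for antiproliferative activity (on this read-out higher numbers stand for weaker inhibition and lower numbers for stronger inhibition), compound 3 (`CC(C)=CCc1cc(C(=O)Nc2cc3ccc(OCCCN(C)C(C)C)c(C)c3oc2=O)ccc1O`) gives 1050 nM. Compound 2 (`CC(C)=CCc1cc(C(=O)Nc2cc3ccc(OCCCNC(C)C)c(C)c3oc2=O)ccc1O`) gives 740 nM, and the step between them is a 1.4-fold higher number from compound 2 to compound 3 (0.15 log units; within the scatter). Compound 1 (`CC(C)=CCc1cc(C(=O)Nc2cc3ccc(OCC4CCCN(C)C4)c(C)c3oc2=O)ccc1O`) gives 2640 nM, which places compound 3 clearly below it.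

Compound 4 (`COC(=O)CNCCCOc1ccc2cc(NC(=O)c3ccc(O)c(CC=C(C)C)c3)c(=O)oc2c1C`) has ((methoxycarbonyl)methyl)amino in place of isopropyl(methyl)amino on a saturated chain carbon, three bonds along the chain from an oxygen on an aromatic ring.

Within the data shown here, no measured compound carries a methoxycarbonyl group, so the evidence is indirect. Adding a methyl on the amine nitrogen gave only a 1.4-fold higher number from compound 2 to compound 3 (0.15 log units; within the scatter). The larger replacements of the whole amine group gave modest steps: a 3.6-fold lower number from compound 1 to compound 2 (0.55 log units; beyond the scatter) and a 2.5-fold lower number from compound 1 to compound 3 (0.40 log units; beyond the scatter). Those sizes suggest a small change here, with an uncertain direction. The expected step is a 1.4-fold higher number from compound 3 to compound 4 (0.15 log units; within the scatter), which would stay within the scatter.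

For compound 4, the estimated value in this assay is 1500 nM, with an expected range of 500 nM to 4500 nM.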

Compound 4, half-maximal inhibitory concentration: 2820 nM
Compound 4: middle estimate off by 1.9-fold (0.27 log units), on the low side, within the range that was stated.
By their numbers in this assay, from the lowest: compounds 2 and 3 (each within the scatter of the next); then compounds 1 and 4 (each within the scatter of the next).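

The change to ((methoxycarbonyl)methyl)amino gives a 2.7-fold higher number from compound 3 to compound 4 (0.43 log units; beyond the scatter), and putting (methoxycarbonyl)methyl in place of isopropyl on the amine nitrogen gives a 3.8-fold higher number from compound 2 to compound 4 (0.58 log units; beyond the scatter), so in this assay the number does respond to the choice of group on this nitrogen, which adding a methyl alone had not shown. The result also brings an open-chain amine level with the ring-containing amine of compound 1, with a 1.1-fold higher number from compound 1 to compound 4 (0.03 log units; within the scatter), so two quite different amine groups can give matching numbers here. Nothing available explains the rise in the number.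

As far as these compounds go, whether the rise belongs to the methyl ester or to the loss of the branched isopropyl group stays open. A carboxylic acid or a plain ethyl group on the same nitrogen would bear on that question.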